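Replacing Fluoro with Trifluoromethyl: Compound 2 to Compound 3

A few compounds are considered here, and "the series" means these few. Any claim that something is new, unique, unknown or untested is made for them only; others in the source may bear on it.

Measured so far in a functional assay on LOX IMVI cells (Homo sapiens) for cytotoxicity, read by MTT assay, with a stated time of 24 h; a higher number here means a weaker inhibitor, a lower number a stronger inhibitor:
Compound 1 `COc1cc(-c2nc(-c3ccccc3)[nH]c2-c2ccnc(NCCCNS(=O)(=O)c3ccccc3)n2)ccc1F`: 4520 nM
Compound 2 `COc1cc(-c2nc(-c3ccccc3)[nH]c2-c2ccnc(NCCCNS(=O)(=O)c3ccc(F)cc3)n2)ccc1F`: 3960 nM

For the measured compounds named here, only two values exist in this assay, and compound 2 at 3960 nM stands level with compound 1 within the scatter. The next compound to be measured is compound 3 `COc1cc(-c2nc(-c3ccccc3)[nH]c2-c2ccnc(NCCCNS(=O)(=O)c3ccc(C(F)(F)F)cc3)n2)ccc1F`. It keeps the shared core of compound 2 and carries trifluoromethyl in place of fluoro on an aromatic carbon, para to a large group (trifluoromethyl in place of fluoro on an aromatic carbon). Going by the values given here, one measured step bears on this change, at the same kind of place: fluoro in place of hydrogen on an aromatic carbon, a 1.1-fold lower number from compound 1 to compound 2 (0.06 log units; within the scatter). That step is small, but it is a single pair and a smaller substituent, so it offers only a loose guide to the larger trifluoromethyl. Among the compounds with values here, no measured compound carries that group. On this evidence, the expected result is a 1.1-fold lower number from compound 2 to compound 3 (0.04 log units; within the scatter), with no change beyond the scatter and no firm direction. For compound 3 the estimated value is 3600 nM, with an expected range from 1700 nM to 7500 nM.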

Compound 3, half-maximal inhibitory concentration: 75200 nM
Compound 3: the middle estimate sits 21-fold (1.32 log units) below what was measured; the measured number lies above the stated range.
By their numbers in this assay, from the lowest: compounds 2 and 1 (each within the scatter of the next); then compound 3.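

In this assay, the aromatic carbon para to a large group turns out not to be indifferent to what it carries. The earlier pair showed only that fluoro could replace hydrogen there with no change beyond the scatter, whereas trifluoromethyl gives a 19-fold higher number from compound 2 to compound 3 (1.28 log units; beyond the scatter) and, measured against the compound with hydrogen at that carbon, a 17-fold higher number from compound 1 to compound 3 (1.22 log units; beyond the scatter); both steps are large and point the same way, so compound 3 is the weakest of the three, and the tolerance seen with fluoro does not extend to trifluoromethyl. Nothing available here offers a measurement that would account for this loss.

With only hydrogen, fluoro and trifluoromethyl shown at this carbon, the compounds leave open whether a chloro, methyl or methoxy group there would stay level with compound 1 and compound 2 or fall away like compound 3. They also leave open whether the same exchange of fluoro for trifluoromethyl would cost as much on a different core or in other cell lines.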